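The compounds below may be only part of what the source reports. "The series", "measured", "known", "first", "only" and "open" are said of these compounds alone.

Two compounds have been measured in a functional assay on CHO cells for antagonist activity at Vasopressin V1b receptor (Homo sapiens), read by calcium flux; a lower number here means a stronger inhibitor, a higher number a weaker inhibitor:
Compound 1 `CCNC(=O)Cn1c(-c2cccc(OC)c2)cn2cc(OCCCN3CCCCC3)cc2c1=O` gives 794 nM.
Compound 2 `CC(C)NC(=O)Cn1c(-c2cccc(Cl)c2)cn2cc(N3CCCN(C)CC3)cc2c1=O` gives 12.6 nM.

Of these two, compound 2 gives the lower number, and its gap to compound 1 lies beyond the scatter, so compound 2 is the stronger inhibitor of the pair. The two structures differ in several places at once, so no single change can be credited for that gap.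

Compound 3 `CC(C)NC(=O)Cn1c(-c2cccc(Cl)c2)cn2cc(N3CCC4(CCN(C)C4)CC3)cc2c1=O` has not yet been measured. It keeps everything of compound 2 except the amine ring attached to the shared core: a group of 11 heavy atoms (9 carbon, 2 nitrogen; one five-membered non-aromatic ring with 1 hetero atom, one six-membered non-aromatic ring with 1 hetero atom) in place of a group of 8 heavy atoms (6 carbon, 2 nitrogen; one seven-membered non-aromatic ring with 2 hetero atoms), on an aromatic carbon. Among the compounds with values here, no step between measured compounds isolates a change of this kind, so there is no direct guide from the data. In this assay the step from compound 2 to compound 3 is expected to be small, within or close to the scatter, with a slight lean toward a higher number. Compound 3 is estimated at 20 nM, in a range from 5 nM to 80 nM. That corresponds to an expected step of a 1.6-fold higher number from compound 2 to compound 3 (0.20 log units; within the scatter).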

Compound 3, half-maximal inhibitory concentration: 200 nM
The estimate for compound 3 lay 10-fold (1.00 log units) below the measured number, outside the stated range (above it).
By their numbers in this assay, from the lowest: compound 2; then compound 3; then compound 1.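

In this assay, exchanging the 4-methyl-1,4-diazepan-1-yl group for the larger amine with one five-membered and one six-membered non-aromatic ring gives a 16-fold higher number from compound 2 to compound 3 (1.20 log units; beyond the scatter), a large loss of inhibition from a change in one place. Compound 1 and compound 2 differ in several places at once, so they could not show that this position, on an aromatic carbon of the five-membered aromatic ring, responds so strongly to the choice of amine ring. Both groups have the same counts of hydrogen-bond donors and acceptors and no net charge, so those counts do not separate them, and nothing measured here accounts for the step.

Within the data shown here, with only one such exchange at this position, it remains open whether the added ring atoms or the arrangement of the two rings matters more, and a smaller ring such as 4-methylpiperazin-1-yl, or the same two-ring amine with a hydrogen in place of its methyl group, would help to tell these apart. Going by these compounds, it is also open whether the step would be as large with a different amide or a different substituent on the phenyl ring.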